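Swapping the fused heteroaromatic on the shared core

The compounds below may be only part of what the source reports. "The series", "measured", "known", "first", "only" and "open" are said of these compounds alone.

Compound 1 `O=C([C@H]1Cc2cc(Cl)cc(-c3ccnc4ccsc34)c2O1)N1CCNCC1` gives 90 nM in an assay on isolated protein for inhibition of ubiquitin carboxyl-terminal hydrolase 7 (Homo sapiens), read by fluorescence, with stated times of 30 min and 1 h (on this read-out higher numbers stand for weaker inhibition and lower numbers for stronger inhibition), the highest number among the three measured compounds. Compound 2 `O=C([C@H]1Cc2cc(Cl)cc(-c3ccnc4cc(CO)sc34)c2O1)N1CCNCC1` gives 43 nM in this assay, and compound 3 `O=C([C@H]1Cc2cc(Cl)cc(-c3ccnc4cc(C(O)(CO)CCl)sc34)c2O1)N1CCNCC1` gives 9 nM. The steps among them are a 2.1-fold lower number from compound 1 to compound 2 (0.32 log units; beyond the scatter), a 10-fold lower number from compound 1 to compound 3 (1.00 log units; beyond the scatter) and a 4.8-fold lower number from compound 2 to compound 3 (0.68 log units; beyond the scatter); all three add or enlarge a substituent on the fused group that compound 1 carries on its core.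

Compound 4 `O=C([C@H]1Cc2cc(Cl)cc(-c3ccnc4[nH]ccc34)c2O1)N1CCNCC1` differs from compound 1 by a group of 9 heavy atoms (7 carbon, 2 nitrogen; one five-membered aromatic ring with 1 hetero atom, one six-membered aromatic ring with 1 hetero atom) in place of a group of 9 heavy atoms (7 carbon, 1 nitrogen, 1 sulfur; one five-membered aromatic ring with 1 hetero atom, one six-membered aromatic ring with 1 hetero atom), on an aromatic carbon. Among the measured compounds shown here, none of the measured steps bears on this exchange: each of them altered a substituent on the group that leaves, whereas here that whole group is replaced, and no measured compound shows what the entering group does. The expectation for compound 4 is therefore a step of a 1.1-fold higher number from compound 1 to compound 4 (0.05 log units; within the scatter) from compound 1, held with little confidence. Compound 4 is estimated at 100 nM in this assay, expected to fall between 25 nM and 400 nM.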

Compound 4, half-maximal inhibitory concentration: 450 nM
For compound 4 the middle estimate is 4.5-fold (0.65 log units) below the measured one; the measured number lies above the stated range.
By their numbers in this assay, from the lowest: compound 3; then compound 2; then compound 1; then compound 4.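

In this assay the exchange of the whole fused group on this aromatic carbon gives a 5.0-fold higher number from compound 1 to compound 4 (0.70 log units; beyond the scatter) so the position responds to the identity of the group itself, and not only to substituents added to it. The two groups match in heavy-atom count and in their five-membered and six-membered aromatic rings, yet the entering group has nitrogen in place of sulfur and carries 1 hydrogen-bond donor and 1 hydrogen-bond acceptor against 0 hydrogen-bond donors and 2 hydrogen-bond acceptors. Nothing at hand tells which of these differences lies behind the higher number.

Going by these compounds, it remains open whether hydroxymethyl would lower the number on the entering group as it does on the group of compound 1. Also open, on these data alone, is what oxygen in place of that sulfur, or a methyl group in place of the hydrogen on the entering group's donor nitrogen, would do.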